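Chain-Terminus Variation on a Shared Bromo-Aza Core

This account rests on a few compounds, and the source may have more. Where it says the series, first, only, none or still open, it means among the compounds named here.

Measured compounds:
- Compound 1 `NCCNc1c(C(=O)NCc2ccc(F)cc2)nc(Br)c2cccnc12`: 12000 nM
- Compound 2 `N[C@H]1CC[C@H](Nc2c(C(=O)NCc3cccs3)nc(Br)c3cccnc23)CC1`: 4100 nM

Of the compounds shown here, two have been tested in a functional assay on MDA-MB-435 cells (Homo sapiens) for cytotoxicity, read by MTT assay, with a stated time of 72 h; a lower number here means a stronger inhibitor, a higher number a weaker inhibitor. Compound 1 gives 12000 nM in this assay, the highest of the two numbers. For the measured compounds named here, its nearest neighbour is compound 2, which gives 4100 nM, a lower number that lies beyond the usual scatter; compound 2 differs from compound 1 in more than one place, so no single step between them can be drawn.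

Compound 3 `CN(C)CCCNc1c(C(=O)NCc2ccc(F)cc2)nc(Br)c2cccnc12` keeps the core and the amide of compound 1 and alters only the chain on the aromatic nitrogen. The change is (dimethylamino)methyl in place of amino on a saturated chain carbon, two bonds along the chain from a nitrogen on an aromatic ring. The chain grows at its far end and its donor count changes, while the acceptor count is kept. Going by the values given here, nothing among the measured compounds isolates this change, so the account rests on compound 1 alone. The expected step of a 1.3-fold lower number from compound 1 to compound 3 (0.12 log units; within the scatter) is small, in the direction of a slightly lower number, and not clearly beyond the scatter. For compound 3 in this assay the estimate is 9000 nM, with a range from 3000 nM to 25000 nM.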

Compound 3, half-maximal inhibitory concentration: 7000 nM
The estimate for compound 3 lay 1.3-fold (0.11 log units) above the measured number; low and high end bracket the measured number.
By their numbers in this assay, from the lowest: compounds 2, 3 and 1 (each within the scatter of the next, the first and the last beyond it).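

For the compounds shown here, this is the first step that can be read at this position, the saturated chain carbon two bonds along the chain from a nitrogen on an aromatic ring: in this assay, (dimethylamino)methyl in place of amino gives a 1.7-fold lower number from compound 1 to compound 3 (0.23 log units; within the scatter). The chain end can therefore go from amino to the larger (dimethylamino)methyl group, which carries no hydrogen-bond donor, without the number leaving the scatter of compound 1, so this single change shows no clear effect in this assay. No measured evidence bears on why the two compounds read alike.

The step lengthens the chain and replaces the amino hydrogens with methyl groups at once, so a compound ending in a plain amine on the longer chain, or one with a dimethylamino group on the shorter chain, would be needed to tell these two parts apart. Going by these compounds, it also remains open whether a carboxylic acid or a morpholine at this chain end would move the number beyond the scatter, and compound 2 differs from compound 3 in more than one place, so nothing here connects its cyclohexane-bearing chain to this series of chain ends.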